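Dimethylamino in place of ethoxy: compound 3 to compound 4

The compounds below may be only part of what the source reports. "The series", "measured", "known", "first", "only" and "open" are said of these compounds alone.

Of the compounds shown here, three have been measured in an assay on lysate for inhibition of patatin-like phospholipase domain-containing protein 2 (Mus musculus), tested at 200 uM; a lower number here means less inhibition, a higher number more inhibition at the concentration tested (going by the name of the read-out). Compound 1 `CCOC(=O)c1cccc(-c2ccc(Br)cc2)c1` gives 34%, compound 2 `CCOC(=O)c1cccc(-c2ccc(C(C)N(C)C)cc2)c1` gives 9%, and compound 3 `CCOc1ccc(-c2cccc(NC(=O)N(C)C)c2)cc1` gives 83%, the highest of the three and beyond the scatter from both others. For the measured compounds named here, the only step between measured compounds that differ in one place, a number 25 percentage points lower from compound 1 to compound 2 (beyond the scatter), moved the number down beyond the scatter.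

Compound 4 `CN(C)C(=O)Nc1cccc(-c2ccc(N(C)C)cc2)c1` differs from compound 3 by dimethylamino in place of ethoxy on an aromatic carbon. The step from compound 1 to compound 2 bears on this only loosely: there a group carrying dimethylamino also entered and the number fell, but the group that left was bromo, not ethoxy, and compound 1 started far lower than compound 3. Going by the values given here, no measured step swaps ethoxy for dimethylamino. The expectation is therefore a drop in this assay, of uncertain size and with a wide range. Compound 4 is expected to give 60%, between 35% and 85%, an estimated step of a number 23 percentage points lower from compound 3 to compound 4 (beyond the scatter).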

Compound 4, a percentage reported as inhibition, at one concentration (the size of the read-out at that concentration, not a potency): 99%
For compound 4 the middle estimate is 39 percentage points below the measured one; measured number outside the range, above it.
By their numbers in this assay, from the lowest: compound 2; then compound 1; then compound 3; then compound 4.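

In this assay, at this position on the aromatic ring, para to a large group, dimethylamino in place of ethoxy goes with a higher number: the change gives a number 16 percentage points higher from compound 3 to compound 4 (beyond the scatter). The two groups match in heavy atoms, hydrogen-bond donors and acceptors and net charge, so these counts do not separate them, yet the read-out still moves beyond the scatter. The other single-place step, a number 25 percentage points lower from compound 1 to compound 2 (beyond the scatter), shows that a group carrying dimethylamino does not lower the number in every setting, since here dimethylamino attached directly to the ring goes with a rise; no measurement of a property of either group bears on this result.

Still open, going by these compounds, is whether a primary amine, a pyrrolidine or a longer alkoxy chain at this position would hold the number. Also open, on these data alone, is whether dimethylamino would give a similar rise on the core of compound 1.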